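This account rests on a few compounds, and the source may have more. Where it says the series, first, only, none or still open, it means among the compounds named here.

Among the compounds with values here, compound 1 `O=C(NCc1cn(Cc2ccc(F)cc2)nn1)c1cn(-c2ccccc2)nc1-c1ccccc1` gives 1600 nM in a functional assay on HeLa cells (Homo sapiens) for antiproliferative activity, read by sulforhodamine B assay, with a stated time of 48 h (on this read-out lower numbers stand for stronger inhibition of growth and higher numbers for weaker inhibition of growth), and stands lowest of the two numbers measured so far. Compound 2 `COc1ccc(Cn2cc(CNC(=O)c3cn(-c4ccccc4)nc3-c3ccccc3)nn2)cc1` gives 6900 nM. The step of a 4.3-fold higher number from compound 1 to compound 2 (0.63 log units; beyond the scatter) goes with methoxy in place of fluoro on an aromatic carbon of the benzyl ring, so the larger group there was accompanied by weaker growth inhibition.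

Compound 3 `COc1ccc(-c2nn(-c3ccccc3)cc2C(=O)NCc2cn(Cc3ccc(F)cc3)nn2)cc1` differs from compound 1 by methoxy in place of hydrogen on an aromatic carbon; cut one bond further out, the change reads phenyl to 4-methoxyphenyl, on the ring attached to the shared core rather than on the benzyl ring. Within the data shown here, the only measured step that bears on it is a 4.3-fold higher number from compound 1 to compound 2 (0.63 log units; beyond the scatter), which introduced the same methoxy group but at a different ring and in exchange for fluoro rather than hydrogen, so it speaks by analogy only. A modest rise, or none beyond the scatter, is therefore expected. For compound 3 the estimate in this assay is 2500 nM, with a range from 800 nM to 8000 nM, which means an expected step of a 1.6-fold higher number from compound 1 to compound 3 (0.19 log units; within the scatter).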

Compound 3, concentration for 50% growth inhibition: 500 nM
Compound 3: middle estimate off by 5.0-fold (0.70 log units), on the high side; the measured number lies below the stated range.
By their numbers in this assay, from the lowest: compound 3; then compound 1; then compound 2.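

In this assay, within the data shown here, the phenyl on the shared core accepts a substituent without loss: phenyl to 4-methoxyphenyl gives a 3.2-fold lower number from compound 1 to compound 3 (0.51 log units; beyond the scatter) and is the first step toward stronger growth inhibition. Methoxy as such therefore does not go with weaker growth inhibition, for the other step with this group, a 4.3-fold higher number from compound 1 to compound 2 (0.63 log units; beyond the scatter), runs the opposite way on the benzyl ring, although there it replaces fluoro rather than hydrogen, so the two steps differ in the group that leaves as well as in their place. No measurement at hand accounts for the gain on this ring, and the direction of a methoxy step is so far tied to only these two places.

Going by these compounds, whether the gain belongs to methoxy itself or would also come with another group on this ring stays open: fluoro, chloro, hydroxy, an amine or a longer alkoxy chain on an aromatic carbon at the same place would separate these readings. Also open, on these data alone, is whether 4-methoxyphenyl keeps its step when the fluoro on the benzyl ring is replaced, and whether the unsubstituted phenyl on the nitrogen of the shared core responds in the same way to methoxy.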